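Chain stereocentre configuration and paw edema inhibition

A few compounds are considered here, and "the series" means these few. Any claim that something is new, unique, unknown or untested is made for them only; others in the source may bear on it.

Of the compounds shown here, three sharing one core have been measured in a functional assay on the whole organism (strain Wistar) for inhibition, with Rattus norvegicus as the target, read by paw edema, with stated times of 1 h and 24 h, at a dose of 10 mg/kg by the intraperitoneal route; a lower number here means less inhibition, a higher number more inhibition at the dose given (going by the name of the read-out). Compound 1 `COc1cc(/C=C/C(=O)/C=C(O)/C=C/c2ccc(OC(=O)[C@@H](CCSC)NC(=O)OCc3ccccc3)c(OC)c2)ccc1OC(=O)[C@@H](CCSC)NC(=O)OCc1ccccc1` gives 90%. Compound 2 `COc1cc(/C=C/C(=O)/C=C(O)/C=C/c2ccc(OC(=O)C(C)NC(=O)OCc3ccccc3)c(OC)c2)ccc1OC(=O)C(C)NC(=O)OCc1ccccc1` gives 100%. Compound 3 `COc1cc(/C=C/C(=O)/C=C(O)/C=C/c2ccc(OC(=O)[C@@H](C)NC(=O)OCc3ccccc3)c(OC)c2)ccc1OC(=O)[C@@H](C)NC(=O)OCc1ccccc1` gives 49%. On these numbers compound 3 stands lowest of the three, with compound 1 nearest and compound 2 furthest above it. Going by the values given here, the single measured step touching configuration is a number 51 percentage points lower from compound 2 to compound 3 (beyond the scatter); what separates that pair is the fact that one of compounds 2 and 3 is drawn with a defined configuration and the other without, at the place where they differ. Compound 4 `COc1cc(/C=C/C(=O)/C=C(O)/C=C/c2ccc(OC(=O)[C@H](C)NC(=O)OCc3ccccc3)c(OC)c2)ccc1OC(=O)[C@H](C)NC(=O)OCc1ccccc1` is not yet measured; against compound 3 the change is the two compounds have the same atoms and bonds and differ only in configuration as drawn: 2 of 5 stereo elements differ; a stereocentre at a saturated chain carbon is drawn R in compound 3 and S in compound 4; a stereocentre at a saturated chain carbon is drawn R in compound 3 and S in compound 4. The step from compound 2 to compound 3 bears on this change directly: compound 2 is drawn without configuration at both chain stereocentres, compound 3 with one configuration at each, and the measured number fell sharply on fixing it. Among the compounds with values here, no measured pair shows a step from one defined configuration to the other, so the direction for compound 4 is read from compound 2 standing well above compound 3. A rise beyond the scatter is therefore expected, estimated as a number 36 percentage points higher from compound 3 to compound 4 (beyond the scatter). For compound 4 in this assay the expected value is 85%, within a range from 50% to 100%.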

Compound 4, a percentage reported as inhibition, in the whole organism at one dose (the size of the read-out at that dose, not a potency): 0%
Compound 4: the middle estimate sits 85 percentage points above what was measured, and the stated range ends above it.
By their numbers in this assay, from the lowest: compound 4; then compound 3; then compounds 1 and 2 (each within the scatter of the next).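

Inverting both chain stereocentres in this assay gives a number 49 percentage points lower from compound 3 to compound 4 (beyond the scatter), which shows that the two defined forms are not equivalent and that the drop tracks configuration alone: the fact that compounds 3 and 4 differ only in the configuration as drawn

Neither defined form reaches the level of the compound drawn without configuration, since the second defined form adds a number 100 percentage points lower from compound 2 to compound 4 (beyond the scatter) to the earlier fall to compound 3, and this pair too is separated only by how configuration is drawn: the fact that one of compounds 2 and 4 is drawn with a defined configuration and the other without, at the place where they differ

The compounds shown do not say what compound 2 consists of, so its high value cannot be assigned to any particular configuration, and they do not separate the contribution of each stereocentre. As far as these compounds go, whether the same dependence on configuration holds when the methyl on the stereocentre gives way to a longer chain, an amine or a carboxylic acid also stays open.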